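The compounds below may be only part of what the source reports. "The series", "measured", "known", "first", "only" and "open" are said of these compounds alone.

Compound 1 `C#CCSc1nnc(CC)n1N1C(=O)c2ccccc2C1=O` and compound 2 `C=CCSc1nnc(CC)n1N1C(=O)c2ccccc2C1=O` share one core and differ only in the unsaturated chain on sulfur. In a functional assay on MKN-45 cells (Homo sapiens) for cytotoxicity, read by MTT assay, with a stated time of 48 h (on this read-out lower numbers stand for stronger inhibition and higher numbers for weaker inhibition), compound 1 gives > 200000 nM, which is a limit of the assay and not a number. In this assay compound 2 likewise gives > 200000 nM, again a limit. The step that the two limits leave unreadable from compound 1 to compound 2 therefore cannot be read, both values sitting at the limit of > 200000 nM in this assay, at which 2 of the 2 values shown sit. On the numbers shown, compound 2 stands only at that limit, without a measured value of its own. Compound 3 `C=CCSc1nnc(CCC)n1N1C(=O)c2ccccc2C1=O` differs from compound 2 by methyl in place of hydrogen on a saturated chain carbon, two bonds along the chain from an aromatic carbon. Going by the values given here, no measured step touches that position, and the one measured step, vinyl for ethynyl, is unreadable. Compound 3 is expected to sit around 300000 nM, estimated between 100000 nM and 1000000 nM, most likely reported again as a limit. The expected step that the limit leaves unreadable from compound 2 to compound 3 is taken as none beyond the scatter.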

Compound 3, half-maximal inhibitory concentration: > 200000 nM
Compound 3 was reported as a limit; the forecaster's own chance of this, stated with the estimate: 85%; the middle value does not contradict the limit.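

No step can be read between compound 2 and compound 3, since in this assay both sit at a limit and not at a number: the limit of > 200000 nM in this assay, at which 3 of the 3 values shown sit.

The compounds shown leave open how large the effect of ethyl to propyl is, and whether any variation on the shared core gives a measured value.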